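The compounds below may be only part of what the source reports. "The series", "measured", "known", "first", "only" and "open" are said of these compounds alone.

In a functional assay on HCT-116 cells (Homo sapiens) for antiproliferative activity, with a stated time of 72 h (on this read-out lower numbers stand for stronger inhibition and higher numbers for weaker inhibition), three compounds have been measured so far:

compound 1 `Cc1[nH]c2ccccc2c1C1=CCC(NCc2ccc(OCC(=O)NO)cc2F)CC1` gives 99 nM
compound 2 `O=C(COc1ccc(CN2CC=C(c3c[nH]c4cccc(F)c34)CC2)cc1)NO` gives 969 nM
compound 3 `Cc1ccc2[nH]cc(C3=CCN(Cc4ccc(OCC(=O)NO)cc4F)CC3)c2c1` gives 1450 nM

Compound 1 stands lowest of the three numbers in this assay. Compound 2 is nearest to it, and its number is higher by an amount beyond the scatter; compound 3 is furthest, also beyond the scatter. On these values compound 1 is the strongest inhibitor of the three.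

The unmeasured compound 4 `O=C(COc1ccc(CNC2CC=C(c3c[nH]c4cccc(F)c34)CC2)c(F)c1)NO` is related to compound 1 by a single change: 4-fluoro-1H-indol-3-yl in place of 2-methyl-1H-indol-3-yl on a double-bonded ring carbon. The rest of the core of compound 1 is kept unchanged. Among the compounds with values here, compound 2 also carries a 4-fluoro-1H-indol-3-yl group, but its remaining structure differs from that of compound 1 in more than one place, so no single step in this assay can be read from compound 1 and compound 2 alone; only their two values are known.

Within the data shown here, with no measured step for this exact change, the expectation for compound 4 is a modest weakening from compound 1, of a 2.2-fold higher number from compound 1 to compound 4 (0.35 log units; beyond the scatter), which may still fall within the scatter. Compound 4 is accordingly estimated at 220 nM in this assay, with a range from 60 nM to 800 nM.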

Compound 4, half-maximal inhibitory concentration: 173 nM
Beside the measured number, compound 4's estimate is 1.3-fold (0.10 log units) above it; the measured number falls inside the stated range.
By their numbers in this assay, from the lowest: compounds 1 and 4 (each within the scatter of the next); then compounds 2 and 3 (each within the scatter of the next).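

In this assay, within the data shown here, the step from 2-methyl-1H-indol-3-yl to 4-fluoro-1H-indol-3-yl on a double-bonded ring carbon is a 1.7-fold higher number from compound 1 to compound 4 (0.24 log units; within the scatter), the first change at this position that can be read on its own, and it stays within the scatter. The earlier compounds shown here could not show this, since they differ from one another in more than one place, whereas this step shows that the position takes either of these two indolyl groups with no difference that can be told apart in this assay. No measurement shown here accounts for the outcome.

Because the methyl group goes and the fluorine arrives in one step, the two compounds cannot show what each does alone, and the plain 1H-indol-3-yl group, with neither, would separate them. Also open is how far this tolerance reaches, since the compounds shown carry only indolyl groups at this place, and a phenyl ring, or an indole bearing a carboxylic acid or an amine, could give a quite different number.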